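The source may hold more compounds than are shown below. What is called first, only, known or untested is meant among the compounds shown, and "the series" means these compounds.

Compound 1, `N#Cc1cc(Cl)c(Nc2nc3c(Nc4ccc(C(F)(F)F)cc4)ncnc3s2)c(Cl)c1`, gives 95 nM in a functional assay on HEK293 cells for antagonist activity at transient receptor potential cation channel subfamily V member 1 (Homo sapiens), read by calcium flux; a lower number here means a stronger inhibitor, a higher number a weaker inhibitor.
Compound 2, `Cc1ccc(Nc2ncnc3sc(Nc4c(Cl)cccc4Cl)nc23)cc1`, gives 33 nM in this assay.

Of the two numbers in hand, compound 2 holds the lowest; its nearest neighbour is compound 1, which shows a higher number, and that gap is beyond the scatter. The two compounds differ in more than one place, so nothing is said here about what drives the gap; the values simply stand as they are.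

Compound 3, `NS(=O)(=O)c1ccc(Nc2ncnc3sc(Nc4c(Cl)cccc4Cl)nc23)cc1`, is the one still to be measured in this assay. Compared with compound 2 it carries a single change: sulfamoyl in place of methyl on an aromatic carbon. Within the data shown here, no pair of measured compounds shows this change, so no step on record tells what it does.

In the absence of such a step, a modest movement towards a higher number in this assay is expected from compound 2 to compound 3, of the size given by a 2.4-fold higher number from compound 2 to compound 3 (0.38 log units; beyond the scatter), though a step within the scatter would not surprise. For compound 3 the estimate in this assay is 80 nM, with a range from 20 nM to 400 nM.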

Compound 3, half-maximal inhibitory concentration: > 5000 nM
Compound 3 was reported as a limit; the forecaster's own chance of this, stated with the estimate: 5%; middle value at least 62-fold (1.79 log units) from the limit.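

In this assay, sulfamoyl in place of methyl on an aromatic carbon, para to a large group, gives an at least 150-fold higher number from compound 2 to compound 3 (2.18 log units; beyond the scatter). Among these compounds, this is the first single-place step, and it shows that this position does not accept every group while keeping the inhibition seen with compound 2. The result for compound 3 is a limit of the assay and not a number: the limit of > 5000 nM in this assay, at which 1 of the 3 values shown sits.

Going by these compounds, the step therefore gives only a minimum size, and the true distance between the two compounds remains unknown. The change also swaps a single carbon for a larger group bearing a hydrogen-bond donor and hydrogen-bond acceptors, and this one step cannot separate those differences from each other.

The compounds shown leave open whether the loss belongs to sulfamoyl itself or would follow any group other than methyl at this position, a question that a methoxy group, an amine or a methylsulfonyl group would help to settle. They also leave open whether the same change would act alike on the other substitution pattern seen in compound 1.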